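Swapping a Small Ring for Dimethylamino on a Pyridine

This account rests on a few compounds, and the source may have more. Where it says the series, first, only, none or still open, it means among the compounds named here.

Of the compounds shown here, three have been tested in an in vitro functional assay on HEK285-7 cells for antagonist activity at prostaglandin D2 receptor 2 (Homo sapiens), read by BRET and beta-arrestin recruitment (a lower number here means a stronger inhibitor, a higher number a weaker inhibitor), and a fourth awaits its turn. Compound 1 `O=C(O)Cc1sc(C(c2ccc(F)cc2)c2ccc(F)cc2)nc1-c1ccnc(N2CCC2)c1` has a value that is only a limit of the measurement, not a number: in this assay compound 1 gives > 100000 nM. Compound 2 `O=C(O)Cc1sc(C2COc3ccccc3O2)nc1-c1ccc(Cl)cc1` gives 2000 nM in this assay. Compound 3 `COc1ccc(C(c2ccccn2)c2nc(-c3ccc(Cl)cc3)c(CC(=O)O)s2)cc1` gives 310 nM in this assay. Compound 1 therefore stands at the weak end of what has been measured, sitting at the limit of > 100000 nM in this assay, at which 1 of the 3 values shown sits.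

Compound 4 `CN(C)c1cc(-c2nc(C(c3ccc(F)cc3)c3ccc(F)cc3)sc2CC(=O)O)ccn1` differs from compound 1 in a single place: dimethylamino in place of azetidin-1-yl on an aromatic carbon. One group is a small ring, the other an open chain, both on the same aromatic carbon, and nothing else in the molecule moves. Going by the values given here, no pair of measured compounds shows this kind of exchange, so there is nothing measured to set the size of its effect. The change is small in size, and the expected step of a number no higher from compound 1 to compound 4 (the limit leaves the size open) is no more than the scatter, in no particular direction. Compound 4 is therefore expected to give about 100000 nM, in a range from 20000 nM to 300000 nM, and most likely the assay will again report only a limit.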

Compound 4, half-maximal inhibitory concentration: > 100000 nM
Compound 4: a limit, no number (the forecaster's own chance of this, stated with the estimate: 70%); the middle value lies on the limit itself.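

Compound 1 and compound 4 each give only a limit of the measurement, not a number, so no step can be read between them: the limit of > 100000 nM in this assay, at which 2 of the 4 values shown sit.

The compounds shown leave open how azetidin-1-yl and dimethylamino compare in this assay on a compound strong enough to give a number there.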